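The compounds below may be only part of what the source reports. "The series", "measured", "known", "first", "only" and "open" are said of these compounds alone.

Working notes on the series. Compound 1, `CCOC(=O)C1=Cc2ccccc2OC1(OCc1cc(-c2ccc(C)cc2)no1)C(F)(F)F`, is the ethyl ester carrying a 4-methylphenyl group. In a functional assay on DU-145 cells (Homo sapiens) for inhibition, read by MTT assay, with a stated time of 24 h (on this read-out lower numbers stand for stronger inhibition and higher numbers for weaker inhibition), compound 1 gives > 150000 nM, which is a limit of the assay rather than a number. Compound 2, `Cc1ccc(-c2cc(COC3(C(F)(F)F)Oc4ccccc4C=C3C(=O)O)on2)cc1`, is the corresponding acid; in this assay compound 2 gives 41400 nM. Going by the values given here, the one measured step, an at least 3.6-fold lower number from compound 1 to compound 2 (0.55 log units; beyond the scatter), concerns hydrogen in place of ethyl on an oxygen next to a carbonyl group and leaves the aryl group untouched. Compound 3, `CCOC(=O)C1=Cc2ccccc2OC1(OCc1cc(-c2ccc(OC)cc2)no1)C(F)(F)F`, differs from compound 1 by methoxy in place of methyl on an aromatic carbon. Among the compounds with values here, no measured step bears on this change, and compound 1 itself sits at the limit of > 150000 nM in this assay, at which 1 of the 2 values shown sits, so there is no number from which a step could be counted. On that basis compound 3 is expected to stay at the limit as well, the estimated step being a number no higher from compound 1 to compound 3 (the limit leaves the size open). The estimate for compound 3 in this assay is 150000 nM, within 60000 nM to 400000 nM.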

Compound 3, half-maximal inhibitory concentration: > 150000 nM
Compound 3 gave a limit, no number (the forecaster's own chance of this, stated with the estimate: 75%); the middle value lies on the limit itself.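

The step between compound 1 and compound 3 cannot be read, because each of the two compounds gives a limit of the assay and not a number: the limit of > 150000 nM in this assay, at which 2 of the 3 values shown sit.

The compounds shown leave open how 4-methoxyphenyl compares with 4-methylphenyl on the shared core in any compound that gives a readable number.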